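Taking the nitro group off compound 1

This account rests on a few compounds, and the source may have more. Where it says the series, first, only, none or still open, it means among the compounds named here.

Compound 1 `CN(C)CCCN(/N=N/c1ccc([N+](=O)[O-])cc1)c1ccccc1` gives 36000 nM
Compound 2 `FC(F)(F)c1cccc(/N=N/N2CCCC2)c1` gives > 100000 nM (a limit of the assay)
Compound 3 `O=[N+]([O-])c1cccc(/N=N/N2CCCC2)c1` gives 42000 nM

All three compounds were measured in an ADME assay on BHK-21 cells (Mesocricetus auratus) for cytotoxicity, read by MTT assay, with a stated time of 96 h (a lower number here means that less compound is tolerated, a higher number that more compound is tolerated), and fall into two groups. Compound 1 lies within the scatter of compound 3, while compound 2 stands apart at its limit.

Compound 4 `CN(C)CCCN(/N=N/c1ccccc1)c1ccccc1` has not yet been measured. It differs from compound 1 by one change, hydrogen in place of nitro on an aromatic carbon.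

Within the data shown here, one measured step bears on this: an at least 2.3-fold lower number from compound 2 to compound 3 (0.37 log units; beyond the scatter), where nitro took the place of trifluoromethyl. As far as these compounds go, its full size stays open because the limit of > 100000 nM in this assay, at which 1 of the 3 values shown sits, applies to its starting point. That step comes from another pair and brings nitro in, whereas here nitro leaves, so it is only a rough guide. A modest rise in this assay is therefore expected, near the edge of the scatter.

The expected change is a 1.9-fold higher number from compound 1 to compound 4 (0.29 log units; within the scatter) on this estimate. For compound 4 the estimated value is 70000 nM, with an expected range of 30000 nM to 140000 nM in this estimate.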

Compound 4, half-maximal cytotoxic concentration: 50000 nM
Estimate against measurement, compound 4: 1.4-fold (0.15 log units) above; the measured number falls inside the stated range.
By their numbers in this assay, from the lowest: compounds 1, 3 and 4 (each within the scatter of the next). At a limit, above all of these: compound 2.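

In this assay, hydrogen in place of nitro on the aromatic carbon para to a large group gives a 1.4-fold higher number from compound 1 to compound 4 (0.14 log units; within the scatter), so on the core of compound 1 the nitro group at this place is not needed for a number in this range. The earlier compounds shown here set nitro only against trifluoromethyl, on another core, and that step lay beyond the scatter, whereas this pair sets nitro against hydrogen alone. Nothing shown accounts for this result.

As far as these compounds go, whether an amine or a carboxylic acid at this place would give a number beyond the scatter of compound 1 stays open. From the compounds shown here alone, it is also open whether hydrogen in place of nitro would read the same on the core of compound 3.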